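The source may hold more compounds than are shown below. What is called first, only, known or untested is meant among the compounds shown, and "the series" means these compounds.

Three analogues built on one shared core have been measured. In a functional assay on the whole organism for inhibition, with Mus musculus as the target, in the writhing test, with a stated time of 1 h, at a dose of 10 mg/kg by the intraperitoneal route (a higher number here means more inhibition at the dose given (going by the name of the read-out), a lower number less inhibition), compound 1 `NC(=O)OC(CCN1CCN(c2ccccc2)CC1)c1cccc(Cl)c1` gives 100%, compound 2 `NC(=O)OC(CCN1CCN(c2ccccc2)CC1)c1ccc(F)cc1` gives 99%, and compound 3 `NC(=O)OC(CCN1CCN(c2ccccc2)CC1)c1ccc([N+](=O)[O-])cc1` gives 100%. Compound 3 stands level with compound 1 at the digits shown, the pair together being the highest of the three numbers; its nearest neighbour is compound 1 with no change at the digits printed from compound 1 to compound 3 (within the scatter), and its furthest is compound 2 with a number 1 percentage points higher from compound 2 to compound 3 (within the scatter). Compound 4 `COc1ccc(C(CCN2CCN(c3ccccc3)CC2)OC(N)=O)cc1` has not yet been measured. It differs from compound 3 by methoxy in place of nitro on an aromatic carbon. The step that bears most directly on this is the swap of one substituent on an aromatic carbon recorded as a number 1 percentage points higher from compound 2 to compound 3 (within the scatter), and the exchange of the whole aryl group recorded as a number 1 percentage points lower from compound 1 to compound 2 (within the scatter) was just as small. Because the swap of one substituent on an aromatic carbon gave a number 1 percentage points higher from compound 2 to compound 3 (within the scatter) and the exchange of the whole aryl group gave a number 1 percentage points lower from compound 1 to compound 2 (within the scatter), no step beyond the scatter is expected for compound 4 in this assay, that is a number 2 percentage points lower from compound 3 to compound 4 (within the scatter). Compound 4 is accordingly estimated to give 98%, with a range from 88% to 100%.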

Compound 4, a percentage reported as inhibition, in the whole organism at one dose (the size of the read-out at that dose, not a potency): 100%
Beside the measured number, compound 4's estimate is 2 percentage points below it; the range from low to high includes it.
By their numbers in this assay, from the lowest: compounds 2, 1, 3 and 4 (each within the scatter of the next).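

In this assay, methoxy in place of nitro on the aromatic carbon para to a large group gave no change at the digits printed from compound 3 to compound 4 (within the scatter) and thus adds a third group at this position, as methoxy in place of fluoro gave a number 1 percentage points higher from compound 2 to compound 4 (within the scatter) too. Exchanging the whole aryl group, with 4-methoxyphenyl in place of 3-chlorophenyl, gave no change at the digits printed from compound 1 to compound 4 (within the scatter) and extends the same picture to this pair. Nitro, with its double bond outside the ring and its two hydrogen-bond acceptors, could thus give way to methoxy, with none of the former and one of the latter, without a step beyond the scatter, and no measurement at hand explains this.

As far as these compounds go, whether an amine or a carboxylic acid on this aromatic carbon would keep the number so close remains open. A single dose also leaves open how the four compounds compare in potency.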